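This account rests on a few compounds, and the source may have more. Where it says the series, first, only, none or still open, it means among the compounds named here.

Compound 1 `O=c1oc2cccnc2n1CCN1CCN(c2ccc(Oc3ccccc3)cc2)CC1` carries a phenoxy group on the aryl ring of the piperazine. In a functional assay on the whole organism with Mus musculus as the target (on this read-out higher numbers stand for an effect only at larger amounts of compound and lower numbers for an effect already at smaller amounts), compound 1 gives only a limit, > 50 mg/kg, so its true dose is not known beyond that bound (the limit of > 50 mg/kg in this assay, at which 1 of the 3 values shown sits). Compound 4 `O=c1oc2cccnc2n1CCN1CCN(c2ccccc2)CC1` differs from compound 1 in one place: hydrogen in place of phenoxy on an aromatic carbon. For the measured compounds named here, no measured step covers this change directly. The measured step that exists, a 1.7-fold lower number from compound 2 to compound 3 (0.23 log units; within the scatter), concerns a different substituent and a shorter linker: compound 2 `O=c1oc2cccnc2n1CN1CCN(c2ccccc2)CC1` gives 5.9 mg/kg in this assay, and compound 3 `O=c1oc2cccnc2n1CN1CCN(c2ccc(F)cc2)CC1` gives 3.5 mg/kg. Both show that the unsubstituted or fluoro-substituted phenylpiperazine in this series reaches an effect at moderate doses, whereas compound 1 with its phenoxy group does not within the tested range. Compound 4 is therefore expected to lie closer to compound 2 than to the limit of compound 1, though the longer linker remains an untested difference. The estimate for compound 4 is 15 mg/kg, with a range from 4 mg/kg to 60 mg/kg, which would mean an expected step of an at least 3.3-fold lower number from compound 1 to compound 4 (0.52 log units; beyond the scatter).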

Compound 4, dose for half-maximal effect: 19.4 mg/kg
Compound 4: middle estimate off by 1.3-fold (0.11 log units), on the low side; the range from low to high includes it.
By their numbers in this assay, from the lowest: compounds 3 and 2 (each within the scatter of the next); then compound 4. At a limit, above all of these: compound 1.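

With the longer linker kept the same, hydrogen in place of phenoxy on an aromatic carbon, para to a large group, gives an at least 2.5-fold lower number from compound 1 to compound 4 (0.41 log units; beyond the scatter) in this assay, a direct reading of this change that the fluoro step on the shorter linker could not provide. Compound 1 gives > 50 mg/kg, and this is a limit of the assay. The step is therefore only a bound, and how much phenoxy costs at this position remains unknown: the limit of > 50 mg/kg in this assay, at which 1 of the 4 values shown sits.

The compounds shown leave open where between hydrogen and phenoxy the dose would fall with a methoxy or a benzyloxy group at this position on the longer linker. They also leave open whether fluoro in place of hydrogen, within the scatter on the shorter linker, would behave the same way on the longer one.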